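Pyrimidin-5-yl for Pyridin-3-yl: Expecting No Change

A few compounds are considered here, and "the series" means these few. Any claim that something is new, unique, unknown or untested is made for them only; others in the source may bear on it.

Compound 1 `COc1ccccc1S(=O)(=O)/C=C/c1cccnc1` gives 100% in an ADME assay on BV-2 cells (Mus musculus) for cytotoxicity, with a stated time of 24 h, tested at 10 uM; on this read-out lower numbers stand for a stronger effect and higher numbers for a weaker effect at the one concentration tested. Compound 2 `COc1ccccc1S(=O)(=O)/C=C/c1cccnc1OC` gives 100%, and compound 3 `COc1ccccc1S(=O)(=O)/C=C/c1cccnc1Cl` gives 99.7%. On these numbers compound 1 is level with compound 2 at the digits shown, and together they hold the highest of the three values; compound 3 lies within the scatter of both. The three measured steps, no change at the digits printed from compound 1 to compound 2 (within the scatter), a number 0.3 percentage points lower from compound 1 to compound 3 (within the scatter) and a number 0.3 percentage points lower from compound 2 to compound 3 (within the scatter), all fall within the scatter, so this assay has so far shown no response to any change in the series.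

Compound 4 `COc1ccccc1S(=O)(=O)/C=C/c1cncnc1` differs from compound 1 by pyrimidin-5-yl in place of pyridin-3-yl on a double-bonded chain carbon bound to a double-bonded chain carbon. Among the measured compounds shown here, no measured step exchanges the ring itself; each replaces a hydrogen or a methoxy on an aromatic carbon. Those steps bear only loosely on the present change, but since every one of them was flat, no step beyond the scatter is expected in this assay. Compound 4 is therefore estimated at 99%, within 88% to 105%, an expected step of a number 1 percentage points lower from compound 1 to compound 4 (within the scatter).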

Compound 4, a percentage reported as activity, at one concentration (the size of the read-out at that concentration, not a potency): 100%
For compound 4 the middle estimate is 1 percentage points below the measured one; the range from low to high includes it.
By their numbers in this assay, from the lowest: compounds 3, 1, 2 and 4 (each within the scatter of the next).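

Among the compounds shown here, the step of no change at the digits printed from compound 1 to compound 4 (within the scatter) is the first to exchange the ring itself rather than a group on it. It shows that this assay gives no step beyond the scatter even when the ring at this double-bonded chain carbon changes, here from 1 hetero atom in pyridin-3-yl to 2 in pyrimidin-5-yl. The data offer no explanation for this flat response.

As far as these compounds go, all four compounds lie within the scatter of one another, so it remains open which change, if any, would produce a step beyond the scatter in this read-out. An amine or a carboxylic acid on the ring, or a longer alkoxy chain in place of the methoxy group, might show whether this flat response holds for less closely related groups.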